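The source may report more compounds than this note shows. Statements on the series, on what has been measured and on what is new or still open speak of the compounds shown alone.

Of the compounds shown here, three have been measured in a functional assay, read by spectrophotometry, with a stated time of 15 min, tested at 60 ug/mL; on this read-out lower numbers stand for a weaker effect and higher numbers for a stronger effect at the one concentration tested. Compound 1 `Clc1ccc(/C=N/Nc2nc(-c3ccccc3)cs2)c(Cl)c1` gives 80.4% in this assay. Compound 2 `COC(=O)c1cc(-c2csc(N/N=C/c3cccs3)n2)ccc1OCc1ccccc1` gives 84.4%. Compound 3 `Fc1ccc(-c2csc(N/N=C/c3ccc(Cl)cc3Cl)n2)cc1` gives 92.4%, the highest of the three numbers: its gap to compound 2 lies within the usual scatter, while its gap to compound 1 lies beyond it. For the measured compounds named here, the single step measured between two compounds that differ in one place, a number 12 percentage points higher from compound 1 to compound 3 (beyond the scatter), is modest in size.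

Compound 4 `COc1ccc(-c2csc(N/N=C/c3ccc(Cl)cc3Cl)n2)cc1` differs from compound 3 in one place: methoxy in place of fluoro on an aromatic carbon. Going by the values given here, no measured pair shows methoxy in place of fluoro, so the only step that bears on the question is the one just described, where fluoro in place of hydrogen on an aromatic carbon gave a modest rise. Methoxy in place of fluoro is a different exchange, and the data hold no step of this kind, so no shift beyond the scatter is expected. Compound 4 is therefore estimated at 88%, with a range from 75% to 97%. The step this estimate means, a number 4.4 percentage points lower from compound 3 to compound 4 (within the scatter), is expected to stay within the usual scatter of this assay.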

Compound 4, a percentage reported as inhibition, at one concentration (the size of the read-out at that concentration, not a potency): 82.8%
The estimate for compound 4 lay 5.2 percentage points above the measured number; measured number inside the range.
By their numbers in this assay, from the lowest: compounds 1, 4, 2 and 3 (each within the scatter of the next, the first and the last beyond it).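

For the compounds shown here, on an aromatic carbon of the six-membered ring, para to a large group, the earlier compounds showed only fluoro against hydrogen; compound 4 adds a second replacement at this place and shows that the two exchanges do not read alike in this assay. Going from 4-fluorophenyl to 4-methoxyphenyl gives a number 9.6 percentage points lower from compound 3 to compound 4 (within the scatter), and methoxy in place of hydrogen gives a number 2.4 percentage points higher from compound 1 to compound 4 (within the scatter), so methoxy cannot be told apart from either fluoro or hydrogen here, even though those two are separated by a number 12 percentage points higher from compound 1 to compound 3 (beyond the scatter). Nothing available explains why these numbers fall as they do.

What the compounds shown leave open is whether any other group at this place, such as an amine, a carboxylic acid or a longer chain like butoxy, would give a step beyond the scatter from hydrogen or from fluoro. They also leave open whether the same picture would hold at other concentrations, since every number here comes from one concentration and none of them is a potency.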